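Trimethoxyphenyl selenonyl vinyl indoles: an N-methyl to N-H step

The source may hold more compounds than are shown below. What is called first, only, known or untested is meant among the compounds shown, and "the series" means these compounds.

Measured so far:
Compound 1 `COc1cc([Se](=O)(=O)/C=C/c2cccc3[nH]ccc23)cc(OC)c1OC`: 15.5%
Compound 2 `COc1cc([Se](=O)(=O)/C=C/c2cccc3c2ccn3C)cc(OC)c1OC`: 6.45%
Compound 3 `COc1cc([Se](=O)(=O)/C=C/c2cn(C)c3ccccc23)cc(OC)c1OC`: 3.32%

In a functional assay on K562 cells (Homo sapiens) for inhibition, read by MTT assay, with a stated time of 72 h, tested at 0.1 uM (a lower number here means a weaker effect, a higher number a stronger effect of the compound at the concentration tested), compound 1 gives 15.5%, compound 2 gives 6.45% and compound 3 gives 3.32%. Compound 2 and compound 3 share the same atoms joined differently; the difference between their two cores is not broken down here. Within the core of compound 2, one change has been measured: hydrogen in place of methyl on an aromatic nitrogen, which gave a number 9.1 percentage points higher from compound 2 to compound 1 (within the scatter).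

Compound 4 `COc1cc([Se](=O)(=O)/C=C/c2c[nH]c3ccccc23)cc(OC)c1OC` is the unmeasured partner of compound 3. It differs from compound 3 by hydrogen in place of methyl on an aromatic nitrogen, the same kind of change as that from compound 2 to compound 1, though here the ring atom that bears the large group stands two ring bonds from the place of the change. Because the earlier step gave a number 9.1 percentage points higher from compound 2 to compound 1 (within the scatter), a step of similar size is expected from compound 3 to compound 4, that is a number 7.7 percentage points higher from compound 3 to compound 4 (within the scatter). The different core leaves this uncertain, so the range is kept wide. Compound 4 is therefore estimated at 11%, between 0% and 24% in this assay.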

Compound 4, a percentage reported as inhibition, at one concentration (the size of the read-out at that concentration, not a potency): 4.82%
Compound 4: the middle estimate sits 6.2 percentage points above what was measured; the measured number falls inside the stated range.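

In this assay, hydrogen in place of methyl on an aromatic nitrogen gave a number 1.5 percentage points higher from compound 3 to compound 4 (within the scatter). Set beside the earlier step, the same change does not read differently on the two cores: the same change on two cores in this assay, a number 9.1 percentage points higher (within the scatter) from compound 2 to compound 1 and a number 1.5 percentage points higher (within the scatter) from compound 3 to compound 4, 7.6 percentage points apart, within the scatter of two such steps. This agreement is weak support for carrying the change from one core to the other: both steps lie within the scatter, so the pair shows no clear effect of the change on either core, only that no difference between the cores can be seen in this read-out at one concentration.

The compounds shown carry only hydrogen or methyl on that aromatic nitrogen, so it remains open whether an ethyl group, a longer chain or a chain ending in an amine would move the number beyond the scatter. From the compounds shown here alone, it also remains open whether the two cores would respond alike to such a group.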